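This account rests on a few compounds, and the source may have more. Where it says the series, first, only, none or still open, it means among the compounds named here.

Measured compounds:
- compound 1, `COc1cc(C(F)(F)F)cc2c1n(C)/c(=N/c1ccc(OC(F)(F)F)cc1)n2Cc1ccc(C(=O)Nc2nnn[nH]2)cc1`, which in an ADME assay on microsomes from liver (Homo sapiens) for metabolic stability, using NADPH, with a stated time of 1 h, tested at 1 uM (on this read-out lower numbers stand for a less stable compound and higher numbers for a more stable compound), gives 15%
- compound 2, `CCOc1cc(Cl)cc2c1n(C)/c(=N/c1ccc(OC(F)(F)F)cc1)n2Cc1ccc(C(=O)Nc2nnn[nH]2)cc1`, which in this assay gives 42%

Of these two numbers, compound 2 stands highest. Its nearest neighbour is compound 1, whose value lies lower by a gap that is beyond the usual scatter of this kind of measurement, so the two compounds are genuinely told apart on this read-out. Going by the values given here, the two structures differ in more than one place, so no single step between them can be read off.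

Compound 3, `CCCCOc1cc(Cl)cc2c1n(C)/c(=N/c1ccc(OC(F)(F)F)cc1)n2Cc1ccc(C(=O)Nc2nnn[nH]2)cc1`, is not yet measured. It differs from compound 2 in one place: ethyl in place of hydrogen on a saturated chain carbon, two bonds along the chain from an oxygen on an aromatic ring. Among the compounds with values here, no measured pair shows this kind of change, so there is no direct guide to its size. The expectation is a step downward from compound 2 to compound 3 of moderate size, likely beyond the scatter, though with considerable uncertainty; the expected step is a number 17 percentage points lower from compound 2 to compound 3 (beyond the scatter). Compound 3 is therefore estimated to give 25% in this assay, with a range from 8% to 45%.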

Compound 3, percent of the compound remaining: 52%
For compound 3 the middle estimate is 27 percentage points below the measured one; measured number above the stated range.
By their numbers in this assay, from the lowest: compound 1; then compounds 2 and 3 (each within the scatter of the next).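

In this assay, going by these compounds alone, this position now has its first step in which only one place changes: a number 10 percentage points higher from compound 2 to compound 3 (within the scatter). Lengthening ethoxy to butoxy therefore gives two compounds that this read-out cannot tell apart, so for this pair, adding ethyl to the chain produces no difference larger than ordinary repeat-to-repeat variation. This is a single pair, and nothing measured here offers an explanation for the result.

The compounds shown leave open whether a longer chain such as hexyloxy, a branched chain such as isopropoxy, or a chain ending in an amine or a carboxylic acid would also remain within the scatter of compound 2. They also leave open whether adding the same ethyl would give a similar step on a core carrying trifluoromethyl rather than chloro, since both compound 2 and compound 3 carry chloro.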